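Swapping a methylphenyl for a pyridinyl on the thiourea amide

The source may report more compounds than this note shows. Statements on the series, on what has been measured and on what is new or still open speak of the compounds shown alone.

Compound 1 `O=C(NC(=S)n1ccc2c(OCCCCCOc3ccc(Cl)cc3)cccc21)c1ccccc1` gives 29500 nM in an ADME assay on Huh-7 cells (Homo sapiens) for cytotoxicity; a higher number here means that more compound is tolerated, a lower number that less compound is tolerated. Compound 2 `O=C(NC(=S)N1CCc2ccc(OCc3ccccc3)cc21)c1ccccc1` gives 43800 nM in this assay. Compound 3 `Cc1ccc(C(=O)NC(=S)N2CCc3c(OCCCCCOc4ccc(Cl)cc4)cccc32)cc1` gives > 50000 nM in this assay.

For compound 3 the result is not a number but a limit of the assay: no toxicity was reached up to the limit of > 50000 nM in this assay, at which 1 of the 3 values shown sits. Compound 1 and compound 2 each give a number; the two numbers lie within the usual scatter of each other, so no order between them can be claimed. Compound 3 sits at the limit, which places it at the tolerated end of these three values.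

Compound 4 `O=C(NC(=S)N1CCc2c(OCCCCCOc3ccc(Cl)cc3)cccc21)c1cccnc1` differs from compound 3 in one place: pyridin-3-yl in place of 4-methylphenyl on a carbonyl carbon. For the measured compounds named here, no measured pair shows a change of this kind, so there is nothing to lean on beyond the values themselves.

Compound 4 is expected to remain near the limit, with a step of a number no higher from compound 3 to compound 4 (the limit leaves the size open) that is not beyond the scatter. Compound 4 is estimated at 50000 nM, within a range of 25000 nM to 100000 nM.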

Compound 4, half-maximal cytotoxic concentration: 11100 nM
Beside the measured number, compound 4's estimate is 4.5-fold (0.65 log units) above it; the whole stated range lies above it.
By their numbers in this assay, from the lowest: compound 4; then compounds 1 and 2 (each within the scatter of the next). At a limit, above all of these: compound 3.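

This position is not silent in this assay: pyridin-3-yl in place of 4-methylphenyl on a carbonyl carbon gives an at least 4.5-fold lower number from compound 3 to compound 4 (0.65 log units; beyond the scatter), meaning that less compound is tolerated. For the compounds shown here, the earlier compounds offered no pair differing in one place, so this is the first single change that can be read directly. Compound 3 stands at a limit and not at a number, so the full size of this step stays unknown: the limit of > 50000 nM in this assay, at which 1 of the 4 values shown sits.

The compounds shown do not tell whether the ring nitrogen or the missing methyl carries the step, and they give no cause for it. A 6-methylpyridin-3-yl, which keeps a methyl on the pyridine, or a pyridin-4-yl, which moves the ring nitrogen, on this same carbonyl carbon would bear on that question.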